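The source may report more compounds than this note shows. Statements on the series, on what has been measured and on what is new or still open speak of the compounds shown alone.

Among the compounds with values here, compound 2 `Brc1ccc(-c2cn3ccnc3c(-c3ccc4ncn(C5CCCCC5)c4c3)n2)cc1` gives 31.2% in a functional assay on HCT-116 cells (Homo sapiens) for inhibition, read by sulforhodamine B assay, with a stated time of 48 h, tested at 10 uM (a lower number here means less inhibition, a higher number more inhibition at the concentration tested (going by the name of the read-out)), the lowest of the two numbers measured so far, while compound 1 `COc1ccc(-c2cn3ccnc3c(-c3ccc4ncn(C5CCCCC5)c4c3)n2)cc1` gives 91.3%. Compound 3 `FC(F)(F)c1cccc(-c2cn3ccnc3c(-c3ccc4ncn(C5CCCCC5)c4c3)n2)c1` differs from compound 2 in one place: 3-(trifluoromethyl)phenyl in place of 4-bromophenyl on an aromatic carbon. Within the data shown here, the only measured step, a number 60.1 percentage points lower from compound 1 to compound 2 (beyond the scatter), changed the group at this same place and was large, so a change here can move the number a great deal, but nothing measured shows which way a trifluoromethyl group would move it. Compound 3 is therefore expected to give 45%, with a range from 10% to 80%. This estimate means a step of a number 13.8 percentage points higher from compound 2 to compound 3 (beyond the scatter).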

Compound 3, a percentage reported as inhibition, at one concentration (the size of the read-out at that concentration, not a potency): 17.6%
For compound 3 the middle estimate is 27.4 percentage points above the measured one; the range from low to high includes it.
By their numbers in this assay, from the lowest: compound 3; then compound 2; then compound 1.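

In this assay the 3-(trifluoromethyl)phenyl group lowers the number further (a number 13.6 percentage points lower from compound 2 to compound 3 (beyond the scatter)), and the distance from the 4-methoxyphenyl group grows (a number 73.7 percentage points lower from compound 1 to compound 3 (beyond the scatter)). Two different replacements of the 4-methoxyphenyl group have now given much lower numbers, so among these three compounds only compound 1 gives high inhibition. No evidence is available on the cause of these drops.

The step from compound 2 to compound 3 changes both the substituent and its place on the phenyl ring, so these two changes cannot be separated. As far as these compounds go, how a phenyl ring carrying an amine or a hydroxyl group would behave here remains open.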